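Ethyl to cyclopropyl on an aromatic nitrogen

The compounds below may be only part of what the source reports. "The series", "measured", "known", "first", "only" and "open" are said of these compounds alone.

- compound 1 `CCn1cnc2c(-c3ccc(F)c(Oc4cnc(C#N)nc4)c3)cnnc21`: 2
- compound 2 `CCn1cnc2c(-c3ccc(F)c(Oc4ccc(C#N)cn4)c3)cnnc21`: 2.3

In a physicochemical assay for lipophilicity (on this read-out lower numbers stand for lower lipophilicity and higher numbers for higher lipophilicity), compound 2 stands at 2.3, and compound 1 lies within the usual scatter of it. Compound 3 `N#Cc1ccc(Oc2cc(-c3cnnc4c3ncn4C3CC3)ccc2F)nc1` differs from compound 2 in one place: cyclopropyl in place of ethyl on an aromatic nitrogen. Among the measured compounds shown here, the only measured step, a number 0.30 log units higher from compound 1 to compound 2 (within the scatter), lies elsewhere, on an oxygen on an aromatic ring. For the measured compounds named here, it therefore gives only a loose guide, and no measured step covers this nitrogen. The expected step in this assay, a number 0.10 log units higher from compound 2 to compound 3 (within the scatter), stays within the scatter, if anything upward. Compound 3 is estimated at 2.4, with an expected range of 2 to 2.8.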

Compound 3, distribution coefficient: 2.3
For compound 3 the middle estimate is 0.10 log units above the measured one; the range from low to high includes it.
By their numbers in this assay, from the lowest: compounds 1, 2 and 3 (each within the scatter of the next).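

Cyclopropyl in place of ethyl on the aromatic nitrogen now has a measured step: in this assay, the change gives no change at the digits printed from compound 2 to compound 3 (within the scatter). For this pair, with 5-cyanopyridin-2-yl on the oxygen, adding a three-membered ring of carbon only at this position leaves the number where it was. Nothing measured here gives a reason for this result. Going by these compounds, whether the same holds with 2-cyanopyrimidin-5-yl on the oxygen remains open. So does the effect on this nitrogen of a longer chain or a chain carrying an amine.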